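Aryl change on the ring nitrogen: compound 3 expected

The compounds below may be only part of what the source reports. "The series", "measured", "known", "first", "only" and "open" are said of these compounds alone.

Measured so far:
compound 1, `CCCC(Oc1cnn(-c2cccc(CC)c2)c1)c1ccc(C(=O)NCCC(=O)O)cc1`, 556 nM
compound 2, `CCCC(Oc1cnn(-c2ccc(Cl)cc2)c1)c1ccc(C(=O)NCCC(=O)O)cc1`, 600 nM

In an assay on isolated protein for displacement of a labelled ligand from Glucagon receptor (Homo sapiens) (on this read-out lower numbers stand for stronger inhibition and higher numbers for weaker inhibition), compound 2 gives 600 nM. It stands at one end of the two numbers, with compound 1 at 556 nM as the nearest point; the gap is given by a 1.1-fold higher number from compound 1 to compound 2 (0.03 log units; within the scatter), so the two are not distinguishable on this read-out.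

Compound 3 `CCCC(Oc1cnn(-c2ccccc2C)c1)c1ccc(C(=O)NCCC(=O)O)cc1` is the next member. Its difference from compound 2 is 2-methylphenyl in place of 4-chlorophenyl on an aromatic nitrogen. Among the measured compounds shown here, the only step that bears on this position is a 1.1-fold higher number from compound 1 to compound 2 (0.03 log units; within the scatter), and that step lies within the scatter, so a change of the aryl group on the ring nitrogen has not yet produced a shift that can be read. No step beyond the scatter is therefore expected for no change at the digits printed from compound 2 to compound 3 (within the scatter). Compound 3 is estimated to give 600 nM, in the range 250 nM to 1500 nM.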

Compound 3, inhibition constant: 14700 nM
Estimate against measurement, compound 3: 25-fold (1.39 log units) below; the measured number lies above the stated range.
By their numbers in this assay, from the lowest: compounds 1 and 2 (each within the scatter of the next); then compound 3.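

The aryl group on the aromatic nitrogen is not indifferent in this assay, as the earlier pair suggested: 2-methylphenyl in place of 4-chlorophenyl gives a large loss (a 25-fold higher number from compound 2 to compound 3 (1.39 log units; beyond the scatter)), and 2-methylphenyl in place of 3-ethylphenyl gives one of similar size (a 26-fold higher number from compound 1 to compound 3 (1.42 log units; beyond the scatter)). Among the compounds shown here, the position therefore accepts 3-ethylphenyl and 4-chlorophenyl with no readable difference between them, yet it does not accept every substituted phenyl, and the earlier compounds gave no sign of this. No measurement in hand accounts for the loss.

The compounds shown cannot separate the effect of the methyl group from that of its place on the phenyl ring, since compound 3 differs from compound 1 and compound 2 in both. Unsubstituted phenyl, 2-chlorophenyl and 4-methylphenyl on the same nitrogen would divide these two questions.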